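The source may hold more compounds than are shown below. What is called first, only, known or untested is meant among the compounds shown, and "the series" means these compounds.

Measured compounds:
- compound 1 `COc1cc(NCc2ccccc2)cc(OC)c1OC` gives > 80000 nM, a limit of the assay.
- compound 2 `C/C=C/C(=O)N(Cc1cccc(O)c1)c1cc(OC)c(OC)c(OC)c1` gives 14100 nM.
- compound 3 `COc1ccc(CN(C(=O)CCCl)c2cc(OC)c(OC)c(OC)c2)cc1O` gives 140 nM.

In a functional assay on MGC-803 cells (Homo sapiens) for inhibition, read by MTT assay, with a stated time of 48 h (on this read-out higher numbers stand for weaker inhibition and lower numbers for stronger inhibition), compound 1 reaches > 80000 nM, which is a limit of the assay and not a number. Among the compounds with values here, compound 2 gives 14100 nM and compound 3 gives 140 nM; both carry an acyl group on the nitrogen that compound 1 lacks, so no single-point step links either to compound 1. Compound 4 `COc1ccc(CNc2cc(OC)c(OC)c(OC)c2)cc1` is not yet measured. It differs from compound 1 by methoxy in place of hydrogen on an aromatic carbon. The secondary amine of compound 1 is kept, and with compound 1 sitting at the limit of > 80000 nM in this assay, at which 1 of the 3 values shown sits, the step is expected to be none beyond the scatter, most likely again a limit. Compound 4 is expected near 60000 nM, within 15000 nM to 200000 nM. The expected step is an at least 1.3-fold lower number from compound 1 to compound 4 (0.12 log units; that floor lies within the scatter).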

Compound 4, half-maximal inhibitory concentration: 11400 nM
Estimate against measurement, compound 4: 5.3-fold (0.72 log units) above; measured number below the stated range.
By their numbers in this assay, from the lowest: compound 3; then compounds 4 and 2 (each within the scatter of the next). At a limit, above all of these: compound 1.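

In this assay methoxy in place of hydrogen on this aromatic carbon, para to a large group, gives an at least 7.0-fold lower number from compound 1 to compound 4 (0.84 log units; beyond the scatter), with the secondary amine kept. An acyl group on the nitrogen is therefore not required for a measurable value in this assay. The size of this step is only a floor, since compound 1 stands at a limit: the limit of > 80000 nM in this assay, at which 1 of the 4 values shown sits.

A hydroxy, an ethoxy or a chlorine on this carbon would show whether the step belongs to methoxy itself. On these data alone, how an acyl group on the nitrogen of compound 4 would move its number stays open.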